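The source may report more compounds than this note shows. Statements on the series, on what has been measured and on what is new or still open speak of the compounds shown alone.

The series rests on a shared core carrying a carbonyl whose substituent is varied. Compound 1 `CCN(CC)S(=O)(=O)c1ccc(S(=O)(=O)N2CCC[C@@H](C(=O)N3CCS(=O)(=O)CC3)C2)cc1` gives 220 nM in a functional assay on MIA PaCa-2 cells (Homo sapiens) for inhibition, read by MTT assay, with a stated time of 3 days; on this read-out higher numbers stand for weaker inhibition and lower numbers for stronger inhibition; compound 2 `CCN(CC)S(=O)(=O)c1ccc(S(=O)(=O)N2CCC[C@@H](C(=O)N3CCC(C(F)(F)F)CC3)C2)cc1` gives 110 nM; compound 3 `CCN(CC)S(=O)(=O)c1ccc(S(=O)(=O)N2CCC[C@@H](C(=O)N3CCC(OC)CC3)C2)cc1` gives 50 nM, the lowest of the three numbers. The step of a 4.4-fold lower number from compound 1 to compound 3 (0.64 log units; beyond the scatter) is modest, and a 2.2-fold lower number from compound 2 to compound 3 (0.34 log units; beyond the scatter) is also modest, while a 2.0-fold lower number from compound 1 to compound 2 (0.30 log units; within the scatter) stays within the scatter. Compound 4 `CCN(CC)S(=O)(=O)c1ccc(S(=O)(=O)N2CCC[C@@H](C(=O)NC3CCOCC3)C2)cc1` differs from compound 3 by (oxan-4-yl)amino in place of 4-methoxypiperidin-1-yl on a carbonyl carbon. For the measured compounds named here, no measured step changes the amide nitrogen from a ring member to one bearing a hydrogen, so the steps seen so far bear on it only loosely: they show that exchanging the whole group on the carbonyl carbon has shifted the number by at most a modest amount. Compound 4 is therefore expected to stay close to compound 3, with the step of a 1.6-fold higher number from compound 3 to compound 4 (0.20 log units; within the scatter) estimated to lie within or only just beyond the scatter. Compound 4 is estimated at 80 nM, within a range from 30 nM to 250 nM.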

Compound 4, half-maximal inhibitory concentration: 1350 nM
Compound 4: the middle estimate sits 17-fold (1.23 log units) below what was measured; measured number above the stated range.
By their numbers in this assay, from the lowest: compound 3; then compounds 2 and 1 (each within the scatter of the next); then compound 4.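

In this assay, for the compounds shown here, the position on the carbonyl carbon proves far more sensitive than the earlier compounds showed: exchanging 4-methoxypiperidin-1-yl for (oxan-4-yl)amino gives a 27-fold higher number from compound 3 to compound 4 (1.43 log units; beyond the scatter). The loss is not specific to that one starting group, as the exchange also gives a 12-fold higher number from compound 2 to compound 4 (1.09 log units; beyond the scatter) and a 6.1-fold higher number from compound 1 to compound 4 (0.79 log units; beyond the scatter), so compound 4 has the highest number of the four. The entering group brings one hydrogen-bond donor where 4-methoxypiperidin-1-yl has none, but the change also alters how the ring is attached, and nothing available here explains the loss.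

The compounds shown leave open whether the amide hydrogen alone matters, which a methyl group on the amide nitrogen of compound 4 would address. They also leave open how an open-chain amine such as diethylamino would behave on this carbonyl carbon.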